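The source may hold more compounds than are shown below. What is called first, only, known or untested is meant among the compounds shown, and "the series" means these compounds.

In a functional assay on MDA-MB-231 cells (Homo sapiens) for inhibition, read by MTT assay, with a stated time of 72 h (a lower number here means a stronger inhibitor, a higher number a weaker inhibitor), compound 1 `C=CC(=O)Nc1cccc(NC(=O)CSc2nc(Nc3ccccc3Br)c3ccccc3n2)c1` gives 15200 nM. Compound 2 `C=CC(=O)Nc1cccc(NC(=O)CSc2nc(Nc3cccc(C)c3)c3ccccc3n2)c1` gives 16800 nM, the higher of the two numbers recorded so far, but the difference is a 1.1-fold higher number from compound 1 to compound 2 (0.04 log units; within the scatter), so neither compound can be called the stronger inhibitor. Compound 3 `C=CC(=O)Nc1cccc(NC(=O)CSc2nc(Nc3cc(OC)c(OC)c(OC)c3)c3ccccc3n2)c1` has not yet been measured. It differs from compound 2 in one place: 3,4,5-trimethoxyphenyl in place of 3-methylphenyl on a nitrogen on an aromatic ring. Among the compounds with values here, the only measured step that bears on this change is the one from compound 1 to compound 2, which also exchanged one aryl group on the same nitrogen for another and stayed within the scatter. With a single aryl swap showing no effect, a further aryl swap at this nitrogen is expected to move the number little, in no firm direction. Compound 3 is therefore estimated at 15000 nM, with a range from 6000 nM to 40000 nM, meaning a step of a 1.1-fold lower number from compound 2 to compound 3 (0.05 log units; within the scatter).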

Compound 3, half-maximal inhibitory concentration: > 50000 nM
Compound 3 ended at the assay's limit (the forecaster's own chance of this, stated with the estimate: 10%); at least 3.3-fold (0.52 log units) between middle value and limit.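

The aryl group on a nitrogen on an aromatic ring is not a free choice in this assay, as the exchange between the first two compounds alone had suggested. 3,4,5-trimethoxyphenyl in place of 3-methylphenyl gives an at least 2.9-fold higher number from compound 2 to compound 3 (0.47 log units; beyond the scatter), and in place of 2-bromophenyl it gives an at least 3.2-fold higher number from compound 1 to compound 3 (0.51 log units; beyond the scatter), so both steps toward weaker inhibition lie beyond the scatter. Compound 3 stands at a limit and not at a number, which makes these steps minimum sizes only: the limit of > 50000 nM in this assay, at which 1 of the 3 values shown sits.

The compounds shown cannot separate the effect of the three methoxy groups taken together from that of any one of them, and a phenyl carrying a single methoxy group would bear on this. They also leave open whether any group at this nitrogen, such as a phenyl carrying an amine or a carboxylic acid, gives a lower number than compound 1 or compound 2.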